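This account rests on a few compounds, and the source may have more. Where it says the series, first, only, none or still open, it means among the compounds named here.

Compound 1 `CC1=C(C(=O)OCc2ccccn2)C(c2ccco2)C2=C(CCCC2=O)N1` gives 1.4 in a physicochemical assay for lipophilicity, measured as octanol-water partition; on this read-out lower numbers stand for lower lipophilicity and higher numbers for higher lipophilicity. Compound 3 `CC1=C(C(=O)OCc2cccnc2)C(c2cccs2)C2=C(CCCC2=O)N1` gives 1.4, and compound 2 `CC1=C(C(=O)OCc2cccnc2)C(c2ccc([N+](=O)[O-])cc2)C2=C(CCCC2=O)N1` gives 1.51. Compound 1 thus stands level with compound 3 at the digits shown, the two together the lowest of the three numbers, while compound 2 is the furthest, though still within the scatter of compound 1. Among the measured compounds shown here, the only measured step, a number 0.11 log units lower from compound 2 to compound 3 (within the scatter), concerns a different exchange on a saturated ring carbon and offers no direct guide here. Compound 4 `CCCC1C(C(=O)OCc2ccccn2)=C(C)NC2=C1C(=O)CCC2` differs from compound 1 by propyl in place of furan-2-yl on a saturated ring carbon. For the measured compounds named here, with no measured step covering this exchange, compound 4 is estimated at 1.9 in this assay, with a range from 1.4 to 2.4. The expected step is therefore a number 0.50 log units higher from compound 1 to compound 4 (beyond the scatter), a modest rise.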

Compound 4, partition coefficient: 2.6
For compound 4 the middle estimate is 0.70 log units below the measured one, outside the stated range (above it).
By their numbers in this assay, from the lowest: compounds 1, 3 and 2 (each within the scatter of the next); then compound 4.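

At this saturated ring carbon, this assay shows a large response to exchanging furan-2-yl for propyl (a number 1.20 log units higher from compound 1 to compound 4 (beyond the scatter)). Among the compounds shown here, the only earlier exchange here, between two ring-bearing groups (a number 0.11 log units lower from compound 2 to compound 3 (within the scatter)), gave no sign of such sensitivity. The position therefore does respond, at least when a group with no ring replaces a five-membered aromatic ring, though no available data account for the size of this step.

Open, on these data alone, is whether a longer chain or a cyclohexyl group at this carbon would extend the step. Also open, as far as these compounds go, is whether propyl gives a similar step on the core of compound 3.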